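Working notes: from 2-methylphenyl to 3-methylphenyl

The compounds below may be only part of what the source reports. "The series", "measured", "known", "first", "only" and "open" are said of these compounds alone.

compound 1 `Cc1ccccc1-n1nc(-c2ccccc2)nc1CNc1ccc(C(=O)NO)cc1`: 12300 nM
compound 2 `O=C(NO)c1ccc(NCc2nc(-c3ccc(F)cc3)nn2-c2ccccc2)cc1`: 8960 nM

In a functional assay on MGC-803 cells (Homo sapiens) for antiproliferative activity, read by MTT assay, with a stated time of 72 h (on this read-out lower numbers stand for stronger inhibition and higher numbers for weaker inhibition), compound 1 stands within the scatter of compound 2, and the two cannot be ordered. Compound 3 `Cc1cccc(-n2nc(-c3ccccc3)nc2CNc2ccc(C(=O)NO)cc2)c1` keeps the core of compound 1 and changes only the group on an aromatic nitrogen, with 3-methylphenyl in place of 2-methylphenyl (3-methylphenyl in place of 2-methylphenyl on an aromatic nitrogen). For the measured compounds named here, no measured pair isolates this change. No step beyond the scatter, in either direction, is expected in this assay for this swap. The estimated step is small (a 1.2-fold lower number from compound 1 to compound 3 (0.09 log units; within the scatter)). Compound 3 is estimated at 10000 nM with an expected range from 4000 nM to 25000 nM in this series.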

Compound 3, half-maximal inhibitory concentration: 13200 nM
Estimate against measurement, compound 3: 1.3-fold (0.12 log units) below; the measured number falls inside the stated range.
By their numbers in this assay, from the lowest: compounds 2, 1 and 3 (each within the scatter of the next).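

In this assay, for the compounds shown here, the swap of 2-methylphenyl for 3-methylphenyl on the aromatic nitrogen gives a 1.1-fold higher number from compound 1 to compound 3 (0.03 log units; within the scatter) as the first measured step that isolates this change. Between these two methylphenyl groups, the position shows no difference that can be read. No measurement here speaks to the reason for this result.

Still open, on these data alone, is whether a carboxylic acid or an amine on this phenyl ring, or a longer chain in place of the methyl, would shift the number beyond the scatter in this assay at all.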